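Replacing Phenethyl with Pyridin-2-yl on the Amide Carbonyl

The source may report more compounds than this note shows. Statements on the series, on what has been measured and on what is new or still open speak of the compounds shown alone.

Compound 1 `O=C(CCc1ccccc1)Nc1nnc(-c2ccc3c(c2)OCCO3)s1` gives 14.2 ug/mL
Compound 2 `O=C(/C=C/c1ccccc1)Nc1nnc(-c2ccc3c(c2)OCCO3)s1` gives 45.4 ug/mL

Both values come from a functional assay on BGC-823 cells (Homo sapiens) for antiproliferative activity, read by MTT assay, with a stated time of 48 h; a lower number here means that less compound is needed, a higher number that more compound is needed for the effect. For the measured compounds named here, compound 1 holds the lower of the two numbers, and compound 2 is its only measured neighbour. Going by the values given here, the single measured step, a 3.2-fold higher number from compound 1 to compound 2 (0.50 log units; beyond the scatter), put 2-phenylethenyl in place of phenethyl on a carbonyl carbon. Compound 3 `O=C(Nc1nnc(-c2ccc3c(c2)OCCO3)s1)c1ccccn1` changes that same place, with pyridin-2-yl in place of phenethyl on a carbonyl carbon. Among the compounds with values here, no measured compound carries pyridin-2-yl, so the evidence is thin. Within the data shown here, the only guide is that the one departure from phenethyl, in compound 2 at 45.4 ug/mL, raised the number. A modest move to a higher number in this assay is therefore expected, though an unchanged number remains possible. The expected step is a 2.0-fold higher number from compound 1 to compound 3 (0.29 log units; within the scatter). Compound 3 is estimated at 28 ug/mL, with an expected range from 9 ug/mL to 85 ug/mL.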

Compound 3, half-maximal effective concentration: 35.8 ug/mL
Compound 3: middle estimate off by 1.3-fold (0.11 log units), on the low side; the measured number falls inside the stated range.
By their numbers in this assay, from the lowest: compound 1; then compounds 3 and 2 (each within the scatter of the next).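

In this assay pyridin-2-yl in place of phenethyl on the carbonyl carbon gave a 2.5-fold higher number from compound 1 to compound 3 (0.40 log units; beyond the scatter) and so became the second replacement at this position to move away from compound 1, which now holds the lowest number against two different groups. Set against 2-phenylethenyl, the same group gave a 1.3-fold lower number from compound 2 to compound 3 (0.10 log units; within the scatter) and so cannot be told apart from it here, even though pyridin-2-yl brings a ring hetero atom that the phenyl ring of phenethyl lacks. Nothing measured explains why phenethyl stands apart from these two groups.

On these data alone, it remains open whether a plain phenyl on the carbonyl carbon would behave like pyridin-2-yl or like phenethyl. The same holds for a longer chain ending in phenyl, and for 3-pyridinylethyl, which would keep the phenethyl chain and carry the ring nitrogen.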